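From Allyl(methyl)amino to (But-3-yn-1-yl)oxy on the Carbonyl

The source may hold more compounds than are shown below. What is called first, only, known or untested is meant among the compounds shown, and "the series" means these compounds.

In an ADME assay on L02 cells (Homo sapiens) for antiproliferative activity, read by MTT assay, with a stated time of 48 h (on this read-out higher numbers stand for weaker inhibition and lower numbers for stronger inhibition), compound 1 (`CCn1c(C(=O)NCCCN(C)C)ccc1C(CC)(CC)c1ccc(OCCC(O)(CC)CC)c(C)c1`) gives 2420 nM and compound 2 (`CCn1c(C(=O)NCCN)ccc1C(CC)(CC)c1ccc(OCCC(O)(CC)CC)c(C)c1`) gives 2940 nM on the same read-out. The comparison shows a 1.2-fold higher number from compound 1 to compound 2 (0.08 log units; within the scatter) and so sets no order between them. Compound 3 (`C=CCN(C)C(=O)c1ccc(C(CC)(CC)c2ccc(OCCC(O)(CC)CC)c(C)c2)n1CC`) gives 1190 nM as the lowest of the three numbers. Two measured steps lead to it, both changing the group on the carbonyl carbon: a 2.0-fold lower number from compound 1 to compound 3 (0.31 log units; beyond the scatter) and a 2.5-fold lower number from compound 2 to compound 3 (0.39 log units; beyond the scatter) are modest in size.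

Compound 4 (`C#CCCOC(=O)c1ccc(C(CC)(CC)c2ccc(OCCC(O)(CC)CC)c(C)c2)n1CC`) has not yet been measured. It carries (but-3-yn-1-yl)oxy in place of allyl(methyl)amino on a carbonyl carbon. Among the compounds with values here, the two steps to compound 3 are the only guide, since they involve the same carbonyl carbon, but no measured compound has an oxygen-linked group there. They suggest that exchanges at this place need not move the number far, so nothing larger than those modest steps is expected. The expected move is a 1.3-fold higher number from compound 3 to compound 4 (0.10 log units; within the scatter) in this assay and amounts to no clear change. The estimated value for compound 4 is 1500 nM with wide uncertainty (expected range 600 nM to 4000 nM).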

Compound 4, half-maximal inhibitory concentration: > 50000 nM
Compound 4 was reported as a limit (the forecaster's own chance of this, stated with the estimate: 8%); middle value at least 33-fold (1.52 log units) away from the limit.
By their numbers in this assay, from the lowest: compound 3; then compounds 1 and 2 (each within the scatter of the next). At a limit, above all of these: compound 4.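

In this assay compound 4 stands at a limit of the assay and not at a number: the limit of > 50000 nM in this assay, at which 1 of the 4 values shown sits. The earlier compounds shown here showed only modest steps or none among three nitrogen-linked groups on the carbonyl carbon, so they gave no sign that this place could move the number far, whereas the exchange for the oxygen-linked (but-3-yn-1-yl)oxy group gives a large step from each of them: an at least 42-fold higher number from compound 3 to compound 4 (1.62 log units; beyond the scatter), an at least 17-fold higher number from compound 2 to compound 4 (1.23 log units; beyond the scatter) and an at least 20-fold higher number from compound 1 to compound 4 (1.31 log units; beyond the scatter). The group on this carbonyl carbon can therefore decide the read-out, and all three large steps, whichever nitrogen-linked group leaves, end in the same oxygen-linked group.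

What the compounds shown leave open is whether the large step belongs to the oxygen that links the group to the carbonyl carbon or to the but-3-yn-1-yl chain with its triple bond, since both differ from allyl(methyl)amino at once. A (but-3-yn-1-yl)amino group or an allyloxy group on the same carbonyl carbon would separate the two, and a carboxylic acid or a simple methyl ester there remains an open case as well.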